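The source may report more compounds than this note shows. Statements on the series, on what has been measured and on what is new or still open speak of the compounds shown alone.

Measured in an in vitro ADME assay on microsomes from liver (Homo sapiens) for metabolic stability; on this read-out lower numbers stand for slow clearance and higher numbers for fast clearance:
- Compound 1 `C[C@H](CC(=O)O)Nc1nccc(-c2c[nH]nc2-c2ccc(Cl)cc2)n1`: < 0.006 mL/min/kg, a limit of the assay and not a number
- Compound 2 `OC1CCCC(c2n[nH]cc2-c2ccnc(NC3CCCC3)n2)C1`: 0.015 mL/min/kg

Of the two readings in this assay, only compound 2 has an actual number, 0.015 mL/min/kg. Going by the values given here, there is thus no series of measured values against which to place it, and no step between measured compounds is available.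

Compound 3 `Clc1ccc(-c2n[nH]cc2-c2ccnc(NC3CCCC3)n2)cc1` differs from compound 2 in one place, with 4-chlorophenyl in place of 3-hydroxycyclohexyl on an aromatic carbon of a five-membered aromatic ring with 2 nitrogen (4-chlorophenyl in place of 3-hydroxycyclohexyl on an aromatic carbon).

The same 4-chlorophenyl is carried by compound 1, whose reading of < 0.006 mL/min/kg is a limit. That compound differs from compound 3 in more than this group, so it offers only a loose guide. No step beyond the scatter is expected in this assay, and no firm direction can be assigned. The estimated step is a 1.3-fold lower number from compound 2 to compound 3 (0.10 log units; within the scatter). For compound 3 the estimated clearance is 0.012 mL/min/kg, with an expected range of 0.006 mL/min/kg to 0.03 mL/min/kg.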

Compound 3, clearance: 0.116 mL/min/kg
Compound 3: the middle estimate sits 9.7-fold (0.99 log units) below what was measured, outside the stated range (above it).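

In this assay the position on the aromatic carbon of the five-membered ring proves sensitive to the group it carries: 4-chlorophenyl in place of 3-hydroxycyclohexyl gives a 7.7-fold higher number from compound 2 to compound 3 (0.89 log units; beyond the scatter), a step beyond the scatter between two groups of equal heavy-atom count. The position is also not the only place that matters, since with 4-chlorophenyl held fixed, cyclopentyl in place of 1-(carboxymethyl)ethyl on the nitrogen on an aromatic ring gives an at least 19-fold higher number from compound 1 to compound 3 (1.28 log units; beyond the scatter) in the same read-out. That second step rests on the reading of compound 1, which is a limit: the limit of < 0.006 mL/min/kg in this assay, at which 1 of the 3 values shown sits.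

From the compounds shown here alone, it remains open whether the first step follows the loss of the hydroxyl, the gain of the chlorine or the aromatic ring itself, and a plain cyclohexyl or an unsubstituted phenyl on the same carbon would separate these. Also open, going by these compounds, is how 3-hydroxycyclohexyl reads with 1-(carboxymethyl)ethyl on the nitrogen, and whether a primary amide in place of the carboxylic acid of that chain would keep the reading of compound 1.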